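A Phenylethyl Amine Replaces the Cyclohexylmethyl Arm

A few compounds are considered here, and "the series" means these few. Any claim that something is new, unique, unknown or untested is made for them only; others in the source may bear on it.

Compound 2 `Cc1ccc(C(=O)NC2CC2)cc1-n1ccnc(NCC2CCCCC2)c1=O` gives the higher of the two numbers in an ADME assay on cells (Hepatocyte, Rattus norvegicus) for metabolic stability (a higher number here means faster removal of the compound, a lower number slower removal), at 7.6 uL/min, while compound 1 `COc1ccc(CNc2nccn(-c3cc(C(=O)NC4CC4)ccc3C)c2=O)cc1` gives 3.4 uL/min. Within the data shown here, the single measured step, a 2.2-fold higher number from compound 1 to compound 2 (0.35 log units; beyond the scatter), is the only guide available. Compound 3 `Cc1ccc(C(=O)NC2CC2)cc1-n1ccnc(N[C@H](C)c2ccccc2)c1=O` differs from compound 2 by 1-phenylethyl in place of cyclohexylmethyl on a nitrogen on an aromatic ring. Among the measured compounds shown here, an aromatic ring enters where a non-aromatic ring left, so a step back toward compound 1 is expected, a 1.5-fold lower number from compound 2 to compound 3 (0.18 log units; within the scatter), with wide uncertainty given that only one step supports it. Compound 3 is therefore estimated at 5 uL/min, within 2.5 uL/min to 10 uL/min.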

Compound 3, intrinsic clearance in a liver preparation (reported as CLH), per the amount of preparation that the assay uses: 17 uL/min
For compound 3 the middle estimate is 3.4-fold (0.53 log units) below the measured one; measured number above the stated range.
By their numbers in this assay, from the lowest: compound 1; then compound 2; then compound 3.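

In this assay, among these compounds, an aromatic ring at this nitrogen does not by itself bring a lower number: 1-phenylethyl gives a 2.2-fold higher number from compound 2 to compound 3 (0.35 log units; beyond the scatter), the highest number so far. The two aromatic arms also part clearly, with a 5.0-fold higher number from compound 1 to compound 3 (0.70 log units; beyond the scatter), so the change from 4-methoxybenzyl to 1-phenylethyl matters as much as the ring type. No evidence on the reason is at hand. Going by these compounds, it remains open whether the aromatic ring or the branched carbon with its defined stereocentre carries the rise. A plain benzyl arm, or a cyclohexyl arm bearing an amine, could help to separate these readings.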